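The compounds below may be only part of what the source reports. "The series", "measured", "known", "first", "only" and "open" are said of these compounds alone.

Measured so far:
Compound 1 `CN(C)c1ccc(C2CC(c3ccc(-n4ccnc4)cc3)=NN2)cc1`: 7.6%
Compound 2 `CN(C)c1ccc(C2CC(c3ccc(-n4cncn4)cc3)=NN2C(=O)CCCl)cc1`: 3.7%
Compound 3 `CC(=O)N1N=C(c2ccc(-n3ccnc3)cc2)CC1c1ccc(N(C)C)cc1`: 5%

In a functional assay on MDA-MB-231 cells (Homo sapiens) for inhibition, read by sulforhodamine B assay, tested at 10 uM (on this read-out higher numbers stand for more inhibition at the one concentration tested (going by the name of the read-out) and lower numbers for less inhibition), compound 3 gives 5%, the second highest of the three numbers, but both other compounds lie within the scatter of it. Compound 4 `CN(C)c1ccc(C2CC(c3ccc(-n4ccnc4)cc3)=NN2C(=O)CCCl)cc1` differs from compound 3 by chloromethyl in place of hydrogen on a saturated chain carbon bound to a carbonyl carbon, turning the acetyl into a (2-chloroethyl)carbonyl group. Within the data shown here, the only measured single step, a number 2.6 percentage points lower from compound 1 to compound 3 (within the scatter), changed the same ring nitrogen and stayed within the scatter. Compound 2 already carries the (2-chloroethyl)carbonyl group on a closely related core and gives 3.7%, again close to compound 3. The step of a number 0.5 percentage points lower from compound 3 to compound 4 (within the scatter) is therefore expected to stay within the scatter. Compound 4 is estimated at 4.5%, between -6% and 15%.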

Compound 4, a percentage reported as inhibition, at one concentration (the size of the read-out at that concentration, not a potency): 2.1%
Estimate against measurement, compound 4: 2.4 percentage points above; the measured number falls inside the stated range.
By their numbers in this assay, from the lowest: compounds 4, 2, 3 and 1 (each within the scatter of the next).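

In this assay, chloromethyl in place of hydrogen on the acetyl gives a number 2.9 percentage points lower from compound 3 to compound 4 (within the scatter), and the whole (2-chloroethyl)carbonyl group in place of hydrogen on the amine nitrogen in the ring gives a number 5.5 percentage points lower from compound 1 to compound 4 (within the scatter), so neither change separates these compounds. With that group kept, 1H-imidazol-1-yl in place of 1H-1,2,4-triazol-1-yl gives a number 1.6 percentage points lower from compound 2 to compound 4 (within the scatter), which also stays within the scatter. Nothing available explains these numbers. From the compounds shown here alone, whether an amine or a longer chain in place of the chloromethyl would move the number beyond the scatter remains open.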